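This account rests on a few compounds, and the source may have more. Where it says the series, first, only, none or still open, it means among the compounds named here.

Working notes on the series. Compound 1 `OC[C@H]1O[C@@H](n2cnc3c(NCc4ccc(Cl)cc4Cl)ncnc32)[C@H](O)[C@@H]1O` is the reference point; in a functional assay on MCF cells (Homo sapiens) for antiproliferative activity, with a stated time of 72 h (a higher number here means a weaker inhibitor, a lower number a stronger inhibitor), compound 1 gives 127000 nM. Compound 2 `OC[C@H]1O[C@@H](n2cnc3c(NCc4ccc(Cl)c(Cl)c4)ncnc32)[C@H](O)[C@@H]1O` carries a 3,4-dichlorophenyl in place of the 2,4-dichlorophenyl, and in this assay compound 2 gives 88800 nM; the step of a 1.4-fold lower number from compound 1 to compound 2 (0.16 log units; within the scatter) is therefore not a real difference on these data. Compound 3 `COc1ccc(CNc2ncnc3c2ncn3[C@@H]2O[C@H](CO)[C@@H](O)[C@H]2O)c(OC)c1` stands at the limit of > 166000 nM in this assay, at which 1 of the 3 values shown sits; its entry > 166000 nM is a limit of the assay and not a number. The steps of an at least 1.3-fold higher number from compound 1 to compound 3 (0.11 log units; that floor lies within the scatter) and an at least 1.8-fold higher number from compound 2 to compound 3 (0.27 log units; that floor lies within the scatter) place compound 3 at the weak end of what has been measured, though neither floor separates it from the other two beyond the scatter. Within the data shown here, all three compounds so far are weak in this assay.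

The next member, compound 4 `Cc1cccc(CNc2ncnc3c2ncn3[C@@H]2O[C@H](CO)[C@@H](O)[C@H]2O)c1O`, differs from compound 3 by 2-hydroxy-3-methylphenyl in place of 2,4-dimethoxyphenyl on a saturated chain carbon bound to a nitrogen on an aromatic ring. The two measured steps that bear on this position, an at least 1.3-fold higher number from compound 1 to compound 3 (0.11 log units; that floor lies within the scatter) and an at least 1.8-fold higher number from compound 2 to compound 3 (0.27 log units; that floor lies within the scatter), are both small, so a change of aryl substituent on this saturated chain carbon has not moved the number beyond the scatter anywhere in the series. Compound 4 is therefore expected to remain near the weak end, with the step of an at least 1.1-fold lower number from compound 3 to compound 4 (0.04 log units; that floor lies within the scatter) expected to lie within the scatter. Compound 4 is estimated at 150000 nM, with a range from 60000 nM to 400000 nM, and a limit rather than a number is a likely outcome.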

Compound 4, half-maximal inhibitory concentration: 6900 nM
Compound 4: middle estimate off by 22-fold (1.34 log units), on the high side; measured number below the stated range.
By their numbers in this assay, from the lowest: compound 4; then compounds 2 and 1 (each within the scatter of the next). At a limit, above all of these: compound 3.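

On a saturated chain carbon bound to a nitrogen on an aromatic ring, the aryl group is not indifferent in this assay: 2-hydroxy-3-methylphenyl gives an 18-fold lower number from compound 1 to compound 4 (1.26 log units; beyond the scatter) and a 13-fold lower number from compound 2 to compound 4 (1.11 log units; beyond the scatter), while the steps among compounds 1, 2 and 3 stayed within the scatter. The same change gives an at least 24-fold lower number from compound 3 to compound 4 (1.38 log units; beyond the scatter), and that size is only a floor, since compound 3 stands at a limit of the assay: the limit of > 166000 nM in this assay, at which 1 of the 4 values shown sits. Against 2,4-dimethoxyphenyl, the entering group brings 1 hydrogen-bond donor where the leaving group has 0, and it is the only group in the series shown that carries a hydroxyl, but this coincidence alone does not establish what drives the step.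

The hydroxyl and the methyl enter together, so the compounds shown do not tell which of them, or whether the pair, accounts for the step. A plain 2-hydroxyphenyl, a 3-methylphenyl or a 2-aminophenyl group at this place would bear on that, as would a 2-methoxy-3-methylphenyl group, which keeps the oxygen and caps the hydroxyl hydrogen.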